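Larger aryl on the saturated ring carbon

The source may report more compounds than this note shows. Statements on the series, on what has been measured and on what is new or still open speak of the compounds shown alone.

The series shares one core. Compound 1 `COc1ccc(-n2nc(Sc3ccc(Cl)cc3)cc(CC[C@@H](C)NC(=O)[C@H]3CNCC[C@@H]3c3ccccc3F)c2=O)cc1` carries 2-fluorophenyl on the saturated ring carbon, and in an assay on CHO cells for binding affinity to Melanocortin receptor 4 (Homo sapiens) (on this read-out lower numbers stand for stronger inhibition and higher numbers for weaker inhibition), compound 1 gives 13 nM. Compound 2 `COc1ccc(-n2nc(Sc3ccc(Cl)cc3)cc(CC[C@@H](C)NC(=O)[C@H]3CNCC[C@@H]3c3ccc(C(F)(F)F)cc3)c2=O)cc1` gives 3.8 nM and compound 3 `COc1ccc(-n2nc(Sc3ccc(Cl)cc3)cc(CC[C@@H](C)NC(=O)[C@H]3CNCC[C@@H]3c3ccc(C)cc3)c2=O)cc1` gives 4.7 nM. Replacing the 2-fluorophenyl gave a 3.4-fold lower number from compound 1 to compound 2 (0.53 log units; beyond the scatter) and a 2.8-fold lower number from compound 1 to compound 3 (0.44 log units; beyond the scatter), while exchanging the two 4-substituted phenyls gave a 1.2-fold higher number from compound 2 to compound 3 (0.09 log units; within the scatter). Compound 3 thus stands second highest of the three numbers, with compound 2 nearest and within the scatter, and compound 1 furthest and beyond it.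

Compound 4 `COc1ccc(-n2nc(Sc3ccc(Cl)cc3)cc(CC[C@@H](C)NC(=O)[C@H]3CNCC[C@@H]3c3ccc4ccccc4c3)c2=O)cc1` differs from compound 3 in one place: naphthalen-2-yl in place of 4-methylphenyl on a saturated ring carbon. Among the compounds with values here, no measured step exchanges a single aromatic ring for a fused pair, so the bearing of the steps is indirect: both aryl changes away from compound 1 lowered the number modestly, and the change between compound 2 and compound 3 stayed within the scatter. Compound 4 is therefore expected in this assay near 4 nM, within 1.5 nM to 12 nM. The expected step is a 1.2-fold lower number from compound 3 to compound 4 (0.07 log units; within the scatter), none beyond the scatter.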

Compound 4, half-maximal inhibitory concentration: 17 nM
The estimate for compound 4 lay 4.3-fold (0.63 log units) below the measured number; measured number above the stated range.
By their numbers in this assay, from the lowest: compounds 2 and 3 (each within the scatter of the next); then compounds 1 and 4 (each within the scatter of the next).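

At this saturated ring carbon, a larger aryl group does not simply continue the gain seen with the 4-substituted phenyls: in this assay, naphthalen-2-yl gives a 3.6-fold higher number from compound 3 to compound 4 (0.56 log units; beyond the scatter) and a 4.5-fold higher number from compound 2 to compound 4 (0.65 log units; beyond the scatter). Against the 2-fluorophenyl the same group gives a 1.3-fold higher number from compound 1 to compound 4 (0.12 log units; within the scatter), so the second aromatic ring forfeits the advantage held by 4-methylphenyl and 4-(trifluoromethyl)phenyl, and more aryl carbon alone does not go with a lower number across these four compounds. No measurement shown accounts for the loss.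

From the compounds shown here alone, whether the loss follows from the fused pair itself or from how it is attached remains open, and naphthalen-1-yl or 4-ethylphenyl at the same carbon would help separate the two. Also open, going by these compounds, is whether a 4-methoxyphenyl would stay with compound 2 and compound 3.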